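Sulfide in place of the acid on the shared core

The source may report more compounds than this note shows. Statements on the series, on what has been measured and on what is new or still open speak of the compounds shown alone.

Measured compounds:
compound 1 `CC(C)(C)c1ccc2nc(N)sc2c1`, in a functional assay on the whole organism with Rattus norvegicus as the target (a lower number here means that less compound is needed, a higher number that more compound is needed for the effect), compound 1 gives 4 mg/kg
compound 2 `COC(=O)Cn1c(=N)sc2cc(OC(F)(F)F)ccc21`, for which this assay reports only a limit, compound 2 at > 10 mg/kg
compound 3 `N=c1sc2cc(OC(F)(F)F)ccc2n1CC(=O)O`, for which this assay again reports only a limit, compound 3 at > 10 mg/kg

Compound 3 thus stands at the limit rather than at a number; this is the limit of > 10 mg/kg in this assay, at which 2 of the 3 values shown sit, and compound 2 shares it. Among the measured compounds shown here, the one measured step, a step that the two limits leave unreadable from compound 2 to compound 3, is therefore unreadable: both ends are limits, and nothing can be said of its size or direction. For the measured compounds named here, compound 1, with a different substitution pattern on the shared core, is the only compound with a numerical value, and no step connects it to compound 3.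

The unmeasured compound 4 `CSCCn1c(=N)sc2cc(OC(F)(F)F)ccc21` differs from compound 3 by (methylsulfanyl)methyl in place of carboxy on a saturated chain carbon bound to an aromatic nitrogen. Going by the values given here, no measured step covers this change; the one step in hand is unreadable, and both compounds carrying a substituent on that nitrogen sit at the limit. The step that the limit leaves unreadable from compound 3 to compound 4 is therefore expected to be small or unreadable, with no direction beyond the scatter to be claimed. Compound 4 is estimated at 15 mg/kg in this assay, between 4 mg/kg and 50 mg/kg, with a sizeable chance that only a limit is returned.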

Compound 4, dose for half-maximal effect: 1 mg/kg
Beside the measured number, compound 4's estimate is 15-fold (1.18 log units) above it, and the stated range ends above it.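

Where the one earlier step on this chain could not be read, both of its ends being limits, this place on a saturated chain carbon bound to an aromatic nitrogen now gives a readable change in this assay: (methylsulfanyl)methyl in place of carboxy gives an at least 10-fold lower number from compound 3 to compound 4 (1.00 log units; beyond the scatter). The same group in place of methoxycarbonyl gives an at least 10-fold lower number from compound 2 to compound 4 (1.00 log units; beyond the scatter), so the lower number appears against both the acid and its methyl ester, not against the acid alone. Both sizes are only minimum sizes because compound 2 and compound 3 each stand at a limit of the assay and not at a number: the limit of > 10 mg/kg in this assay, at which 2 of the 4 values shown sit.

The compounds shown do not tell whether the sulfur or the chain itself carries the step, and a propyl chain, a 2-methoxyethyl chain or a longer thioether chain at the same place would separate the two. Also open, on these data alone, is whether an amine at the end of this chain would stay close to compound 4 or return to the limit.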